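Acyl-isothioureas and selenium analogues in a leukaemia growth assay

This account rests on a few compounds, and the source may have more. Where it says the series, first, only, none or still open, it means among the compounds named here.

The series pairs two diacylated amidine-type cores. Compound 1 `CS/C(=N\C(=O)c1ccno1)NC(=O)c1ccno1` and compound 2 `O=C(/N=C(/NC(=O)c1ccno1)[Se]Cc1ccccc1)c1ccno1` share one core; compound 3 `O=C(/N=C(/NC(=O)c1cc(-c2ccccc2)nc2ccccc12)[Se]Cc1ccccc1)c1cc(-c2ccccc2)nc2ccccc12` and compound 4 `CS/C(=N\C(=O)c1cc(-c2ccccc2)nc2ccccc12)NC(=O)c1cc(-c2ccccc2)nc2ccccc12` share another. The difference between the two cores is not broken down here.

Growth inhibition was read in a functional assay on K562 cells (Homo sapiens) for cytotoxicity, read by MTT assay, with a stated time of 72 h; on this read-out lower numbers stand for stronger inhibition of growth and higher numbers for weaker inhibition of growth. Compound 2 gives 57300 nM in this assay. Compound 3 gives 47400 nM in this assay, and this number and that of compound 2 lie within the scatter of each other. For compound 1 this assay reports only a limit, > 100000 nM, not a number.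

Within the first core the change from compound 2 to compound 1 is a group of 2 heavy atoms (1 carbon, 1 sulfur; no ring) in place of a group of 8 heavy atoms (7 carbon, 1 selenium; one six-membered aromatic ring of carbon only), on a carbon with a double bond to nitrogen. It gave an at least 1.7-fold higher number from compound 2 to compound 1 (0.24 log units; that floor lies within the scatter); the size of that step is open at the top because of the limit of > 100000 nM in this assay, at which 1 of the 3 values shown sits.

Within the second core the change from compound 3 to compound 4 is a group of 2 heavy atoms (1 carbon, 1 sulfur; no ring) in place of a group of 8 heavy atoms (7 carbon, 1 selenium; one six-membered aromatic ring of carbon only), on a carbon with a double bond to nitrogen, the same change made on the same kind of carbon with the same neighbours. From compound 3 to compound 4 a step of a 2.0-fold higher number from compound 3 to compound 4 (0.30 log units; within the scatter) is expected in this assay, resting on the step from compound 2 to compound 1 an at least 1.7-fold higher number from compound 2 to compound 1 (0.24 log units; that floor lies within the scatter). Compound 4 is therefore estimated at 95000 nM in this assay, with a range from 45000 nM to 250000 nM, and a real chance that only a limit is reported.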

Compound 4, concentration for total growth inhibition: > 100000 nM
Compound 4 was reported as a limit; the forecaster's own chance of this, stated with the estimate: 50%; at least 1.0-fold (0.02 log units) between middle value and limit.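

In this assay, methylsulfanyl in place of the selenium-bearing ring group, on a carbon with a double bond to nitrogen, gives an at least 2.1-fold higher number from compound 3 to compound 4 (0.32 log units; beyond the scatter), and the comparison with the other core reads: the same change on two cores in this assay, an at least 1.7-fold higher number (0.24 log units; that floor lies within the scatter) from compound 2 to compound 1 and an at least 2.1-fold higher number (0.32 log units; beyond the scatter) from compound 3 to compound 4; the limit leaves it open whether they differ

Compound 4 is reported only as a limit, > 100000 nM, not a number.

The change thus moves the number the same way on both cores, though only the floor on the second core lies beyond the scatter, and nothing shows that the step has the same size on each core, because the measured range ends at the limit: the limit of > 100000 nM in this assay, at which 2 of the 4 values shown sit.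

The change swaps selenium for sulfur and removes the aromatic ring in one move, so the compounds shown leave open which of the two goes with the higher number; a methylselanyl or a benzylsulfanyl group on the same carbon would separate them. Also open, from the compounds shown here alone, is how a longer chain on sulfur, or an amine at that carbon, would read on either core.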